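Aryl variation at the pyridine position: indole replacing benzodioxin

The source may hold more compounds than are shown below. What is called first, only, known or untested is meant among the compounds shown, and "the series" means these compounds.

The series shares one core and differs only in the aryl group attached to it. Compound 1 `CC(C(=O)NCc1ccc(C(F)(F)F)nc1-c1ccc(C(C)(C)C)cc1)c1ccc(NS(C)(=O)=O)c(F)c1` gives 0.5 nM in an assay on CHO cells for antagonist activity at transient receptor potential cation channel subfamily V member 1 (Homo sapiens), read by FLIPR; on this read-out higher numbers stand for weaker inhibition and lower numbers for stronger inhibition. Compound 2 `COc1ccc(-c2nc(C(F)(F)F)ccc2CNC(=O)C(C)c2ccc(NS(C)(=O)=O)c(F)c2)cc1OC` gives 25.6 nM. Compound 3 `CC(C(=O)NCc1ccc(C(F)(F)F)nc1-c1ccc2c(c1)OCCO2)c1ccc(NS(C)(=O)=O)c(F)c1` gives 5 nM, the second highest of the three numbers; its nearest neighbour is compound 2, its furthest is compound 1. Three steps at this position are measured: a 51-fold higher number from compound 1 to compound 2 (1.71 log units; beyond the scatter), a 10-fold higher number from compound 1 to compound 3 (1.00 log units; beyond the scatter) and a 5.1-fold lower number from compound 2 to compound 3 (0.71 log units; beyond the scatter). All three lie beyond the scatter, so exchange of the aryl group here has moved the number substantially in every case so far, with the two fused and oxygen-bearing variants both giving higher numbers than the tert-butyl compound.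

Compound 4 `CC(C(=O)NCc1ccc(C(F)(F)F)nc1-c1ccc2cc[nH]c2c1)c1ccc(NS(C)(=O)=O)c(F)c1` is not yet measured. Relative to compound 3 the change is 1H-indol-6-yl in place of 2,3-dihydro-1,4-benzodioxin-6-yl on an aromatic carbon; the entering group is again bicyclic, but it carries 1 hydrogen-bond donor and 0 hydrogen-bond acceptors in place of 0 donors and 2 acceptors. Among the compounds with values here, no measured step involves such a group, so the direction cannot be read from the measured steps; their size suggests a change of modest to large magnitude is possible. Compound 4 is expected to give about 8 nM, within 2 nM to 40 nM, meaning an estimated step of a 1.6-fold higher number from compound 3 to compound 4 (0.20 log units; within the scatter).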

Compound 4, inhibition constant: 20.3 nM
Estimate against measurement, compound 4: 2.5-fold (0.40 log units) below; measured number inside the range.
By their numbers in this assay, from the lowest: compound 1; then compound 3; then compounds 4 and 2 (each within the scatter of the next).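

In this assay the change to 1H-indol-6-yl gives a 4.1-fold higher number from compound 3 to compound 4 (0.61 log units; beyond the scatter) and so is a second bicyclic group at this position that does not match the tert-butyl compound, with a 41-fold higher number from compound 1 to compound 4 (1.61 log units; beyond the scatter) as the gap. The position also now shows its first pair of different aryl groups that cannot be separated: a 1.3-fold lower number from compound 2 to compound 4 (0.10 log units; within the scatter) places 1H-indol-6-yl and 3,4-dimethoxyphenyl level, even though only the former has a five-membered aromatic ring with a hetero atom. No data on any other property accompany these numbers, so the steps remain without an explanation.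

The compounds shown leave open whether the hydrogen on the indole nitrogen plays any part in the step, a question that a 1-methylindol-6-yl group would address directly. Also open, from the compounds shown here alone, is how far the 4-(tert-butyl)phenyl result extends, for instance to a phenyl group carrying an isopropyl group, a longer alkyl chain, an amine or a carboxylic acid at the place of the tert-butyl group.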